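A few compounds are considered here, and "the series" means these few. Any claim that something is new, unique, unknown or untested is made for them only; others in the source may bear on it.

Measured compounds:
Compound 1 `Cc1nc(N)c2nc(-c3ccccc3)sc2n1` in a functional assay on CHO cells for antagonist activity at adenosine receptor A2b (Homo sapiens), read by cAMP accumulation, with a stated time of 10 min (on this read-out lower numbers stand for stronger inhibition and higher numbers for weaker inhibition), gives > 30000 nM, which is a limit of the assay and not a number.
Compound 2 `Nc1nc(-c2ccccc2)nc2sc(-c3ccccc3)nc12` in this assay gives > 30000 nM, again a limit and not a number.
Compound 3 `COc1cccc(-c2nc(N)c3nc(-c4ccccc4)sc3n2)c1` in this assay gives > 30000 nM, also a limit and not a number.

Compound 3 therefore stands nowhere on a scale: its value is a limit only, and the other two values in the series are the same limit, as the limit of > 30000 nM in this assay, at which 3 of the 3 values shown sit, records. Every step among the measured compounds is consequently unreadable: a step that the two limits leave unreadable from compound 1 to compound 2, a step that the two limits leave unreadable from compound 1 to compound 3 and a step that the two limits leave unreadable from compound 2 to compound 3 give no size and no direction.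

The next compound is compound 4 `Nc1nc(-c2cccc(O)c2)nc2sc(-c3ccccc3)nc12`, reached from compound 3 by the change (hydrogen in place of methyl on an oxygen on an aromatic ring). Within the data shown here, none of the measured steps concerns this oxygen; they replace methyl on an aromatic carbon by phenyl or 3-methoxyphenyl, or hydrogen by methoxy, and none of them could be read in any case. No size can be carried over to this step.

With three limits and nothing else, the expectation for compound 4 is a value near the same limit, estimated at 25000 nM, within 3000 nM to 100000 nM. The step of an at least 1.2-fold lower number from compound 3 to compound 4 (0.07 log units; that floor lies within the scatter) is accordingly expected to be none beyond the scatter, with a real chance that this assay again returns only a limit.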

Compound 4, half-maximal inhibitory concentration: > 30000 nM
Compound 4: only a limit was reported (the forecaster's own chance of this, stated with the estimate: 65%); middle value at least 1.2-fold (0.07 log units) away from the limit.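

In this assay compound 4 gives > 30000 nM, a limit of the assay and not a number. The steps to compound 4 from compound 1, compound 2 and compound 3 cannot be read, in size or in direction. The series stands at a single limit: the limit of > 30000 nM in this assay, at which 4 of the 4 values shown sit.

The compounds shown leave open whether any change on the shared core gives a measurable value in this assay.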